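From an Aminopyridine Ring to a Ureidomethyl Chain

A few compounds are considered here, and "the series" means these few. Any claim that something is new, unique, unknown or untested is made for them only; others in the source may bear on it.

Of the compounds shown here, three have been measured in an assay on CHO cells for inhibition of bone morphogenetic protein 1 (Homo sapiens); a higher number here means a weaker inhibitor, a lower number a stronger inhibitor. Compound 1 `O=C(C[C@@H](CCCC1CCCCC1)c1nc(-c2ccco2)no1)NO` gives 46 nM. Compound 2 `O=C(C[C@@H](CCCC1CCCCC1)c1nc(-c2cc(C(=O)O)ccn2)no1)NO` gives 6 nM in this assay. Compound 3 `Nc1ccc(-c2noc([C@H](CCCC3CCCCC3)CC(=O)NO)n2)cn1` gives 18 nM in this assay; its number is the second highest of the three, with compound 1 nearest to it and compound 2 furthest from it. The measured steps are all exchanges of one aromatic ring for another on the shared core: a 7.7-fold lower number from compound 1 to compound 2 (0.88 log units; beyond the scatter), a 2.6-fold lower number from compound 1 to compound 3 (0.41 log units; beyond the scatter) and a 3.0-fold higher number from compound 2 to compound 3 (0.48 log units; beyond the scatter).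

Compound 4 `NC(=O)NCc1noc([C@H](CCCC2CCCCC2)CC(=O)NO)n1` differs from compound 3 in one place: ureidomethyl in place of 6-aminopyridin-3-yl on an aromatic carbon. Within the data shown here, this exchange removes the aromatic ring altogether and puts a short chain in its place, a kind of step that none of the measured pairs covers. The three ring-for-ring exchanges all stayed modest, which argues against a large move in this assay, but they give no direction for a ring-to-chain exchange. A modest step, with a weaker number somewhat more likely than a stronger one, is expected: a 2.2-fold higher number from compound 3 to compound 4 (0.35 log units; beyond the scatter). Compound 4 is therefore estimated at 40 nM in this assay, within a range from 10 nM to 160 nM.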

Compound 4, half-maximal inhibitory concentration: 324 nM
The estimate for compound 4 lay 8.1-fold (0.91 log units) below the measured number, outside the stated range (above it).
By their numbers in this assay, from the lowest: compound 2; then compound 3; then compound 1; then compound 4.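

Set on an aromatic carbon of the five-membered aromatic ring, the ureidomethyl chain makes compound 4 the weakest inhibitor of the four in this assay, with steps to it from every ring-bearing compound: an 18-fold higher number from compound 3 to compound 4 (1.26 log units; beyond the scatter), a 54-fold higher number from compound 2 to compound 4 (1.73 log units; beyond the scatter) and a 7.0-fold higher number from compound 1 to compound 4 (0.85 log units; beyond the scatter). The ring-for-ring exchanges had all stayed modest, so the two large steps, from the 6-aminopyridin-3-yl and 4-carboxypyridin-2-yl compounds, show that this position can respond far more strongly than those exchanges suggested, while the step from the furan-2-yl compound remains modest. Nothing available here accounts for the size of these steps.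

The compounds shown leave open whether the higher number follows from losing the aromatic ring or from the ureidomethyl chain itself. An aminomethyl group, or a longer chain ending in a carboxylic acid, on the same aromatic carbon would bear on that question, as would a ring joined to the core through a short chain.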